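Swapping the Bicyclic Ring Beyond the Ether Linker

The compounds below may be only part of what the source reports. "The series", "measured", "known", "first", "only" and "open" are said of these compounds alone.

Compound 1 `CC(C)(C)Sc1c(CC(C)(C)C(=O)O)n(Cc2ccc(Cl)cc2)c2ccc(CCc3ccc4ccccc4n3)cc12` and compound 2 `CC(C)(C)Sc1c(CC(C)(C)C(=O)O)n(Cc2ccc(Cl)cc2)c2ccc(OCc3ccc4cccnc4n3)cc12` share one core and differ only in the two-ring group hanging off it. In a functional assay for inhibition, with Homo sapiens as the target (on this read-out lower numbers stand for stronger inhibition and higher numbers for weaker inhibition), compound 1 gives 4 nM, and compound 2 gives 6 nM. The step of a 1.5-fold higher number from compound 1 to compound 2 (0.18 log units; within the scatter) shows that the two numbers lie within the usual scatter of each other, so neither compound can be set above the other.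

Compound 3 `Cc1nc2ccc(COc3ccc4c(c3)c(SC(C)(C)C)c(CC(C)(C)C(=O)O)n4Cc3ccc(Cl)cc3)cc2s1` again keeps the core and alters only the far bicyclic group: a group of 10 heavy atoms (8 carbon, 1 nitrogen, 1 sulfur; one five-membered aromatic ring with 2 hetero atoms, one six-membered aromatic ring of carbon only) in place of a group of 10 heavy atoms (8 carbon, 2 nitrogen; 2 six-membered aromatic rings with 1 hetero atom each), on a saturated chain carbon bound to an oxygen on an aromatic ring. Among the measured compounds shown here, only the step from compound 1 to compound 2 bears on this, as it also reshaped the outer two-ring group, and it stayed within the scatter. The expectation is therefore a step of a 1.3-fold higher number from compound 2 to compound 3 (0.12 log units; within the scatter), no larger than the scatter. Compound 3 is estimated at 8 nM in this assay, within the range 3 nM to 25 nM.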

Compound 3, half-maximal inhibitory concentration: 6 nM
For compound 3 the middle estimate is 1.3-fold (0.12 log units) above the measured one, and the stated range covers the measured number.
By their numbers in this assay, from the lowest: compounds 1, 2 and 3 (each within the scatter of the next).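

In this assay the 2-methyl-1,3-benzothiazol-6-yl group replaces the earlier group with two six-membered aromatic rings, each holding one hetero atom, and the result is no change at the digits printed from compound 2 to compound 3 (within the scatter). This position, on a saturated chain carbon bound to an oxygen on an aromatic ring, therefore tolerates a group with a five-movered sulfur-containing aromatic ring without any change beyond the scatter. The larger replacement on an aromatic carbon gives a 1.5-fold higher number from compound 1 to compound 3 (0.18 log units; within the scatter), so all three compounds remain indistinguishable in this read-out, and no available evidence bears on why these different groups read alike.

All the groups shown here contain two fused rings, so it remains open how a single phenyl ring would read at this position. Also open, from the compounds shown here alone, is what a carboxylic acid or an amine on the outer ring would do, or a plain hydrogen in place of the methyl on compound 3.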